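The source may report more compounds than this note shows. Statements on the series, on what has been measured and on what is new or still open speak of the compounds shown alone.

Measured so far in a functional assay for inhibition, with Homo sapiens as the target (a lower number here means a stronger inhibitor, a higher number a weaker inhibitor), with these results:
- compound 1 `O=C(O)CCCCCCn1nc(-c2ccccc2)c(-c2ccccc2)c1-c1ccccc1` gives 22400 nM 
- compound 2 `O=C(O)CCCCCCCCn1cc(-c2ccccc2)cn1` gives > 105000 nM (a limit of the assay, not a number)
- compound 3 `O=C(O)CCCCCCCCn1cc(-c2ccccc2)c(-c2ccccc2)n1` gives 4500 nM 

Only two of these results are true numbers. Compound 1 at 22400 nM has the higher one and compound 3 at 4500 nM has the lower one, so compound 1 sits at the weaker end of those two.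

Compound 4 `O=C(O)C[S+]([O-])CCCCCCn1nc(-c2ccccc2)c(-c2ccccc2)c1-c1ccccc1` keeps the core of compound 1 and changes only the chain end, as a group of 6 heavy atoms (2 carbon, 3 oxygen, 1 sulfur; no ring) in place of a group of 3 heavy atoms (1 carbon, 2 oxygen; no ring), on a saturated chain carbon, six bonds along the chain from an aromatic nitrogen shows: a group of 6 heavy atoms (2 carbon, 3 oxygen, 1 sulfur; no ring) stands in place of a group of 3 heavy atoms (1 carbon, 2 oxygen; no ring), on a saturated chain carbon, six bonds along the chain from an aromatic nitrogen.

Within the data shown here, the only measured step, an at least 23-fold lower number from compound 2 to compound 3 (1.36 log units; beyond the scatter), is large, but it places a phenyl on an aromatic carbon and leaves the chain end alone. It therefore gives no direct guide. A modest expected drop rests on compound 3 at 4500 nM with a chain longer than that of compound 1, as in compound 4, although its core differs. The expected change is a 2.8-fold lower number from compound 1 to compound 4 (0.45 log units; beyond the scatter) and remains uncertain. For compound 4 the estimated value is 8000 nM with a likely range from 2000 nM to 30000 nM in this assay here.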

Compound 4, half-maximal inhibitory concentration: 6500 nM
Compound 4: middle estimate off by 1.2-fold (0.09 log units), on the high side; the range from low to high includes it.
By their numbers in this assay, from the lowest: compounds 3 and 4 (each within the scatter of the next); then compound 1. At a limit, above all of these: compound 2.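

In this assay the swap at the chain end gives a 3.4-fold lower number from compound 1 to compound 4 (0.54 log units; beyond the scatter) and shows that this end of the chain can be rebuilt without a loss of inhibition. Among these compounds, the earlier step changed a phenyl on an aromatic carbon and left the chain end alone, so this is the first direct reading for a saturated chain carbon, six bonds along the chain from an aromatic nitrogen. The entering group of 6 heavy atoms still holds a hydrogen-bond donor and adds a hydrogen-bond acceptor, but nothing measured here accounts for the lower number.

The entering group changes several things at once, adding a sulfur, an oxygen and more chain, so the result cannot say which of these matters. As far as these compounds go, it also remains open whether the core of compound 1 would keep or improve this level of inhibition with a sulfone, an amide or a tetrazole at the chain end, or with a plain longer chain ending in the carboxy group.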